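A Second Halogen Pattern on the Pendant Phenyl Ring

The source may report more compounds than this note shows. Statements on the series, on what has been measured and on what is new or still open speak of the compounds shown alone.

The measured compounds and their values:
compound 1 `COc1cccc(/C=C2\CCC/C(=C\c3ccc(O)c(Cl)c3)C2=O)c1OC`: 16800 nM in a functional assay on SW-620 cells (Homo sapiens) for cytotoxicity, read by MTT assay, with a stated time of 72 h; on this read-out higher numbers stand for weaker inhibition and lower numbers for stronger inhibition
compound 2 `COc1ccc(/C=C2\CCC/C(=C\c3ccccc3Cl)C2=O)cc1OC`: 7100 nM
compound 3 `COc1ccc(/C=C2\CCC/C(=C\c3ccc(Br)cc3)C2=O)cc1OC`: 5200 nM

Compound 3 gives the lowest of these three numbers. Its nearest neighbour is compound 2: a 1.4-fold lower number from compound 2 to compound 3 (0.14 log units; within the scatter), so the two are not separated beyond the usual scatter. Compound 1 stands furthest away, with a number that is higher than that of compound 3 by more than the scatter, though no single change connects the two.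

Compound 4 `COc1ccc(/C=C2\CCC/C(=C\c3cc(Cl)cc(Cl)c3)C2=O)cc1OC` differs from compound 3 in one place: 3,5-dichlorophenyl in place of 4-bromophenyl on a double-bonded chain carbon bound to a double-bonded ring carbon. Among the compounds with values here, only one measured step bears on this change, the exchange of one halogenated phenyl for another at the same place, a 1.4-fold lower number from compound 2 to compound 3 (0.14 log units; within the scatter), which stayed within the scatter. The step of a 1.3-fold lower number from compound 3 to compound 4 (0.11 log units; within the scatter) is therefore expected to be small and probably within the scatter as well. Compound 4 is expected to give about 4000 nM, with a range from 1500 nM to 12000 nM.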

Compound 4, half-maximal inhibitory concentration: 2500 nM
Compound 4: the middle estimate sits 1.6-fold (0.20 log units) above what was measured, within the range that was stated.
By their numbers in this assay, from the lowest: compound 4; then compounds 3 and 2 (each within the scatter of the next); then compound 1.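

In this assay, the double-bonded chain carbon bound to a double-bonded ring carbon does respond to the choice of halogenated phenyl: there is a 2.1-fold lower number from compound 3 to compound 4 (0.32 log units; beyond the scatter) and a 2.8-fold lower number from compound 2 to compound 4 (0.45 log units; beyond the scatter) when 3,5-dichlorophenyl enters. Within the data shown here, the exchange of 2-chlorophenyl for 4-bromophenyl had stayed within the scatter, so these are the first steps at this place to go beyond it. Nothing measured here explains why the number falls with this group.

The compounds shown leave open whether the change depends on having two halogens, on their placement on the ring, or on chlorine rather than bromine. Also open, as far as these compounds go, is how a phenyl ring carrying an amine or a carboxylic acid would behave at this place.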